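The compounds below may be only part of what the source reports. "The series", "measured", "known", "first", "only" and "open" are said of these compounds alone.

Measured in a functional assay on NCI-H460 cells (Homo sapiens) for cytotoxicity, read by MTT assay, with a stated time of 72 h; on this read-out higher numbers stand for weaker inhibition and lower numbers for stronger inhibition:
- compound 1 `CC(C)(C)c1[nH]cnc1/C=c1\[nH]c(=O)/c(=C/c2cccc(Oc3ccc(F)cc3)c2)[nH]c1=O`: 4 nM
- compound 2 `O=C(c1ccc(F)cc1)c1cccc(/C=c2\[nH]c(=O)/c(=C/c3nc[nH]c3C3CC3)[nH]c2=O)c1`: 2.8 nM
- compound 3 `O=C(c1ccc(F)cc1)c1cccc(/C=c2\[nH]c(=O)/c(=C/c3c[nH]cn3)[nH]c2=O)c1`: 278 nM

Compound 1, at 4 nM, lies within the usual scatter of compound 2, at 2.8 nM. Compound 3, at 278 nM, stands well above both and marks the weak end of this small set.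

The next compound is compound 4 `O=c1[nH]/c(=C\c2ccccn2)c(=O)[nH]/c1=C\c1cccc(Oc2ccc(F)cc2)c1`, which keeps the core of compound 1 and its 4-fluorophenoxy-bearing side. The change is pyridin-2-yl in place of 5-(tert-butyl)-1H-imidazol-4-yl on a double-bonded chain carbon bound to an aromatic carbon.

Among the measured compounds shown here, no measured compound carries pyridin-2-yl, so no measured step shows this exchange directly. The nearest evidence is a 99-fold higher number from compound 2 to compound 3 (2.00 log units; beyond the scatter), a large rise in the number when hydrogen replaces cyclopropyl on the imidazole. Compound 4 likewise has no group in the place of the tert-butyl, although that step comes from a different series and involves a smaller change.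

A large step towards a higher number is therefore expected in this assay, of similar size to that one. The step expected is a 63-fold higher number from compound 1 to compound 4 (1.80 log units; beyond the scatter). For compound 4 the estimated value is 250 nM, with an expected range from 50 nM to 1200 nM.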

Compound 4, half-maximal inhibitory concentration: 49.1 nM
Compound 4: middle estimate off by 5.1-fold (0.71 log units), on the high side; the whole stated range lies above it.
By their numbers in this assay, from the lowest: compounds 2 and 1 (each within the scatter of the next); then compound 4; then compound 3.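

In this assay, putting pyridin-2-yl in place of 5-(tert-butyl)-1H-imidazol-4-yl on this double-bonded chain carbon gives a 12-fold higher number from compound 1 to compound 4 (1.09 log units; beyond the scatter), so this place also responds to an exchange of the whole ring. The earlier step, a 99-fold higher number from compound 2 to compound 3 (2.00 log units; beyond the scatter), came from another series and concerned only the loss of cyclopropyl from an imidazole that stayed in place. Compound 4 still gives 49.1 nM, which shows that an imidazole at this place is not required for a measurable effect in this assay.

Nothing in the data accounts for the size of this step. The compounds shown do not separate the loss of the tert-butyl group from the exchange of the imidazole for the pyridine, as none of them pairs an unsubstituted imidazole with the 4-fluorophenoxy-bearing side or a tert-butyl group with pyridin-2-yl, and they do not tell how a pyridin-2-yl carrying an amine or a methyl group would behave.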